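Methylsulfonyl in place of trifluoromethoxy on the sulfonamide series

A few compounds are considered here, and "the series" means these few. Any claim that something is new, unique, unknown or untested is made for them only; others in the source may bear on it.

Compound 1 `CN(C)CC[C@H](CSc1ccccc1)Nc1ccc(S(=O)(=O)NC(=O)c2ccc(N3CCN(Cc4ccccc4-c4ccc(Cl)cc4)CC3)cc2)cc1OC(F)(F)F` has been measured in an assay on isolated protein for displacement of a labelled ligand from Apoptosis regulator Bcl-2 (Homo sapiens), read by fluorescence polarization; on this read-out lower numbers stand for stronger inhibition and higher numbers for weaker inhibition. In this assay compound 1 gives < 1 nM, which is a limit of the assay and not a number. Two further analogues of the same series have been run. In this assay compound 2 `CN(C)CC[C@H](CSc1ccccc1)Nc1ccc(S(=O)(=O)NC(=O)c2ccc(N3CCN(CC4=C(c5ccc(Cl)cc5)CCC(C)(C)C4)CC3)cc2)cc1[N+](=O)[O-]` gives < 1 nM, again a limit. In this assay compound 3 `CN(C)CC[C@H](CSc1ccccc1)Nc1ccc(S(=O)(=O)NC(=O)c2ccc(N3CCN(CC4=C(c5ccc(Cl)cc5)CCC4)CC3)cc2)cc1[N+](=O)[O-]` gives < 1 nM, also a limit. For the measured compounds named here, all three values therefore sit at the same point, (the limit of < 1 nM in this assay, at which 3 of the 3 values shown sit), and no ordering among compounds 1, 2 and 3 can be read from them; no step between measured compounds is available.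

Compound 4 `CN(C)CC[C@H](CSc1ccccc1)Nc1ccc(S(=O)(=O)NC(=O)c2ccc(N3CCN(Cc4ccccc4-c4ccc(Cl)cc4)CC3)cc2)cc1S(C)(=O)=O` differs from compound 1 in one place: methylsulfonyl in place of trifluoromethoxy on an aromatic carbon. Nothing measured in the series speaks to this exchange, so the expectation rests on the position of compound 1 at the limit alone. The step from compound 1 to compound 4 in this assay is expected to be an at least 1.2-fold higher number from compound 1 to compound 4 (0.07 log units; that floor lies within the scatter), that is, no change beyond the scatter in either direction. For compound 4 in this assay a value of 1.2 nM is estimated, with a range from 0.3 nM to 5 nM, and a fair chance that only a limit is reported again.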

Compound 4, inhibition constant: < 1 nM
Compound 4: a limit, no number (the forecaster's own chance of this, stated with the estimate: 50%); at least 1.2-fold (0.07 log units) between middle value and limit.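

In this assay compound 4 gives < 1 nM, a limit and not a number. For the compounds shown here, compound 1 also stands at a limit, so no step between compound 1 and compound 4 can be read: the limit of < 1 nM in this assay, at which 4 of the 4 values shown sit. The size and direction of the exchange of trifluoromethoxy for methylsulfonyl stay open, as does any ordering among the compounds shown.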